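The source may report more compounds than this note shows. Statements on the series, on what has been measured and on what is new or still open speak of the compounds shown alone.

Compound 1 `COc1cc(N2CCN(C(=O)N[C@@H](C)c3cccc4ccccc34)CC2)ccc1-n1cnc(C)n1` was tested in an ADME assay on microsomes from liver (Rattus norvegicus) for metabolic stability, read by LC-MS (on this read-out higher numbers stand for fast clearance and lower numbers for slow clearance), and gives 110 mL.min-1.g-1. Two other compounds that share its core were measured in this assay: compound 2 `COc1cc(N2CCN(C(=O)Cn3cnc4cc(C(F)(F)F)ccc43)C[C@@H]2C)ccc1-c1cnc(C)o1` gives 67 mL.min-1.g-1, and compound 3 `COc1cc(C2CCN(C(=O)N[C@@H](C)c3cccc4ccccc34)CC2)ccc1-c1cnc(C)o1` gives 170 mL.min-1.g-1. The number for compound 1 lies in the middle of these three, and its gaps to compound 2 and to compound 3 both lie within the scatter of repeated measurements, so the three compounds cannot be told apart on this read-out.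

Compound 4 `COc1cc(N2CCN(C(=O)N[C@@H](C)c3cccc4ccccc34)CC2)ccc1-c1cnc(C)o1` has not yet been measured. It differs from compound 1 in a single place: 2-methyl-1,3-oxazol-5-yl in place of 3-methyl-1H-1,2,4-triazol-1-yl on an aromatic carbon. Among the measured compounds shown here, no measured pair in this set shows exactly this exchange, so its effect on clearance is unknown here. Compound 3 carries the same 2-methyl-1,3-oxazol-5-yl group and gives 170 mL.min-1.g-1, a number within the scatter of compound 1.

The step from compound 1 to compound 4 is therefore expected to be small, a 1.2-fold higher number from compound 1 to compound 4 (0.07 log units; within the scatter), not beyond the scatter in either direction. Compound 4 is estimated at 130 mL.min-1.g-1, with a likely range from 65 mL.min-1.g-1 to 260 mL.min-1.g-1.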

Compound 4, intrinsic clearance in microsomes: 130 mL.min-1.g-1
Compound 4: the middle estimate sits on the measured number at the digits printed, and the stated range covers the measured number.
By their numbers in this assay, from the lowest: compounds 2, 1, 4 and 3 (each within the scatter of the next, the first and the last beyond it).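

Compound 1 and compound 4 are the only pair shown that differs at this position alone, and in this assay placing 2-methyl-1,3-oxazol-5-yl where 3-methyl-1H-1,2,4-triazol-1-yl stood gives a 1.2-fold higher number from compound 1 to compound 4 (0.07 log units; within the scatter). On this read-out, the two groups cannot be told apart on this aromatic carbon, although the ring that enters has 2 hetero atoms rather than 3 and the group has 2 hydrogen-bond acceptors rather than 3. No measurement is available that would explain this result.

Going by these compounds, whether a quite different group here, such as an amine or a carboxylic acid, would move clearance beyond the scatter remains open. On these data alone, it is also open whether the same exchange would give so small a step with a different group on the rest of the molecule.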